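Fluoro in place of bromo: compound 3 to compound 4

The compounds below may be only part of what the source reports. "The series", "measured", "known", "first", "only" and "open" are said of these compounds alone.

Values so far in a functional assay on HeLa cells (Homo sapiens) for inhibition (on this read-out higher numbers stand for weaker inhibition and lower numbers for stronger inhibition), are:
compound 1 `O=C1O/C(=C\Cn2cc(C(F)(F)F)c(=O)[nH]c2=O)C(OCc2ccccc2)=C1OCc1ccccc1` gives 60000 nM
compound 2 `O=C1O/C(=C\Cn2ccc(=O)[nH]c2=O)C(OCc2ccccc2)=C1OCc1ccccc1` gives 50000 nM
compound 3 `O=C1O/C(=C\Cn2cc(Br)c(=O)[nH]c2=O)C(OCc2ccccc2)=C1OCc1ccccc1` gives 30000 nM

At 30000 nM compound 3 cannot be separated from the other two compounds, as every gap among the three lies within the scatter.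

Compound 4 `O=C1O/C(=C\Cn2cc(F)c(=O)[nH]c2=O)C(OCc2ccccc2)=C1OCc1ccccc1` changes a single place of compound 3 with fluoro in place of bromo on an aromatic carbon and so carries fluoro in place of bromo on an aromatic carbon.

Three measured exchanges at this same place bear on the change. There is a 1.2-fold lower number from compound 1 to compound 2 (0.08 log units; within the scatter) with hydrogen in place of trifluoromethyl. There is a 1.7-fold lower number from compound 2 to compound 3 (0.22 log units; within the scatter) with bromo in place of hydrogen. There is a 2.0-fold lower number from compound 1 to compound 3 (0.30 log units; within the scatter) with bromo in place of trifluoromethyl. Among the compounds with values here, all three stay within the scatter, but none of the measured compounds carries fluoro, so the new group itself remains untested.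

On these steps, no step beyond the scatter is expected in this assay and no firm direction can be given. The estimated step is a 1.2-fold lower number from compound 3 to compound 4 (0.08 log units; within the scatter) on this reading. The estimate for compound 4 is 25000 nM with 5000 nM to 60000 nM as the expected range.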

Compound 4, half-maximal inhibitory concentration: 40000 nM
Estimate against measurement, compound 4: 1.6-fold (0.20 log units) below; measured number inside the range.
By their numbers in this assay, from the lowest: compounds 3, 4, 2 and 1 (each within the scatter of the next).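

With fluoro, this position now has four groups measured, and in this assay every exchange to the new group stays flat: a 1.3-fold higher number from compound 3 to compound 4 (0.12 log units; within the scatter) with fluoro in place of bromo, a 1.3-fold lower number from compound 2 to compound 4 (0.10 log units; within the scatter) with fluoro in place of hydrogen, and a 1.5-fold lower number from compound 1 to compound 4 (0.18 log units; within the scatter) with fluoro in place of trifluoromethyl. Fluoro was the one group whose effect here could only be estimated, and it now falls in the same band as hydrogen, bromo and trifluoromethyl, so across compounds 1 to 4 no group at this place separates from any other and no order among them can be stated. No measurement at hand accounts for this flat picture or links it to any feature of these groups.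

Whether any group at this place can move the number beyond the scatter remains open, since an amine, a carboxylic acid, a nitrile and a longer chain such as propyl are not among the compounds shown. Also open, going by these compounds, is whether a change elsewhere on the shared core would give a step that this position does not.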